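The source may report more compounds than this note shows. Statements on the series, on what has been measured and on what is new or still open speak of the compounds shown alone.

Of the compounds shown here, three built on one shared core have so far been tested in an assay on cell membranes for activation of P2Y purinoceptor 1 (Meleagris gallopavo); a lower number here means that less compound is needed, a higher number that more compound is needed for the effect. Compound 1, `Nc1ncnc2c1ncn2C1C(O)C(O)C2(COP(=O)(O)OP(=O)(O)OP(=O)(O)O)CC12`, gives 14 nM. Compound 2, `CSc1nc(N)c2ncn(C3C(O)C(O)[C@@]4(COP(=O)(O)OP(=O)(O)OP(=O)(O)O)C[C@@H]34)c2n1`, gives 3.7 nM, the lowest of the three numbers. Compound 3, `C[S+]([O-])c1nc(N)c2ncn([C@H]3[C@H](O)[C@H](O)[C@@]4(COP(=O)(O)O)C[C@H]34)c2n1`, gives 36.6 nM. Among them compound 2 stands lowest; the number of compound 1 lies nearest to it, with a gap beyond the scatter, and the number of compound 3 lies furthest from it, again beyond the scatter.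

The next compound, compound 4, is `Nc1nc(Cl)nc2c1ncn2C1C(O)C(O)[C@@]2(COP(=O)(O)OP(=O)(O)OP(=O)(O)O)C[C@@H]12`. It differs from compound 2 in a single place: chloro in place of methylsulfanyl on an aromatic carbon. Among the compounds with values here, no measured pair shows this exchange, so its effect cannot be read from any step already in hand. What can be seen is that compound 1, which lacks the methylsulfanyl group, gives 14 nM, a number above that of compound 2. On that basis compound 4 is expected to land somewhat above compound 2, and the step of a 2.2-fold higher number from compound 2 to compound 4 (0.33 log units; beyond the scatter) is estimated to be small, close to the edge of the scatter. In this assay compound 4 is expected to give about 8 nM, within a range from 2.5 nM to 25 nM.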

Compound 4, half-maximal effective concentration: 3 nM
Compound 4: middle estimate off by 2.7-fold (0.43 log units), on the high side, and the stated range covers the measured number.
By their numbers in this assay, from the lowest: compounds 4 and 2 (each within the scatter of the next); then compound 1; then compound 3.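

In this assay, chloro in place of methylsulfanyl on an aromatic carbon between two ring nitrogen atoms gives a 1.2-fold lower number from compound 2 to compound 4 (0.09 log units; within the scatter), so the read-out does not separate the two compounds. Within the data shown here, this is the first step read directly at this position, and it shows that going from a group of two heavy atoms, one of them sulfur, to a single chlorine atom, and from one counted hydrogen-bond acceptor to none, leaves the number within the scatter. Nothing measured here bears on why the two groups read alike.

This single pair leaves open whether other groups at this position, such as an amine, a methoxy group or a longer chain like hexylsulfanyl, would stay as close to compound 2 or move clearly away from it. Among these compounds, it also leaves open whether chloro and methylsulfanyl would still read alike on a compound carrying the shorter phosphate chain of compound 3, since the one step in hand comes from the triphosphate series alone.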